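Solubility along a substituted bicyclic amide series

A few compounds are considered here, and "the series" means these few. Any claim that something is new, unique, unknown or untested is made for them only; others in the source may bear on it.

Measured so far:
compound 1 `CCCS(=O)(=O)Nc1ccc(F)c(C(=O)Nc2cnc3[nH]ncc3c2)c1F` gives 150 ug/mL in a physicochemical assay for solubility, read by HPLC, in phosphate buffer, with a stated time of 24 h, at pH 7.4; on this read-out lower numbers stand for lower solubility and higher numbers for higher solubility
compound 2 `CCCS(=O)(=O)Nc1ccc(F)c(C(=O)Nc2cnc3[nH]nc(OC)c3c2)c1F` gives 9 ug/mL in this assay

Among the measured compounds shown here, compound 2 stands lowest of the two numbers; the only step so far, a 17-fold lower number from compound 1 to compound 2 (1.22 log units; beyond the scatter), separates it from compound 1. Compound 3 `CCCS(=O)(=O)Nc1ccc(F)c(C(=O)Nc2cnc3[nH]nc(Br)c3c2)c1F` carries a bromo in place of methoxy on an aromatic carbon. For the measured compounds named here, no measured step covers a bromo at this position, so the step from compound 1 to compound 2 is the only guide and speaks only to substitution at this carbon being tolerated poorly. For compound 3 the estimate is therefore a 1.8-fold lower number from compound 2 to compound 3 (0.26 log units; within the scatter), giving an expected 5 ug/mL (range 1 ug/mL to 25 ug/mL).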

Compound 3, solubility: 3 ug/mL
The estimate for compound 3 lay 1.7-fold (0.22 log units) above the measured number; measured number inside the range.
By their numbers in this assay, from the lowest: compound 3; then compound 2; then compound 1.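

In this assay, bromo in place of methoxy on this aromatic carbon of the five-membered aromatic ring gives a 3.0-fold lower number from compound 2 to compound 3 (0.48 log units; beyond the scatter), so the outcome here depends on which group is present, not only on whether the carbon is substituted. Bromo in place of hydrogen gives a 50-fold lower number from compound 1 to compound 3 (1.70 log units; beyond the scatter), which adds a second substituent well under the unsubstituted compound. Nothing on hand bears on the reason for either step. Still open, from the compounds shown here alone, is whether an amine or a carboxylic acid on this carbon would give a number nearer that of compound 1.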